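A Methoxy Added to the Sulfonyl Ring

The source may hold more compounds than are shown below. What is called first, only, known or untested is meant among the compounds shown, and "the series" means these compounds.

Of the compounds shown here, two sharing the same core have been measured in an assay on Sf9 cells for inhibition of mitogen-activated protein kinase kinase kinase 20 (Homo sapiens), read by ADP-Glo, with a stated time of 30 min; on this read-out lower numbers stand for stronger inhibition and higher numbers for weaker inhibition. Compound 1 `COc1n[nH]c2ncc(-c3nc(-c4c(F)ccc(NS(=O)(=O)c5cccc(Cl)c5)c4F)no3)cc12` gives 29 nM in this assay. Compound 2 `COc1n[nH]c2ncc(-c3cn(-c4c(F)ccc(NS(=O)(=O)c5ccccc5)c4F)nn3)cc12` gives 3.8 nM, the lowest of the two numbers; compound 1 stands at a higher number, and the gap between the two lies beyond the usual scatter. Since the two differ in more than one place, their values alone cannot be tied to any single change.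

Compound 3 `COc1cccc(S(=O)(=O)Nc2ccc(F)c(-n3cc(-c4cnc5[nH]nc(OC)c5c4)nn3)c2F)c1` has not yet been measured in this assay. It differs from compound 2 in one place: methoxy in place of hydrogen on an aromatic carbon. Going by the values given here, no measured pair shows this change on its own, so there is no step to lean on, and the account rests on the value of compound 2 alone. The methoxy entering on the ring that carries the sulfonyl is expected to shift the number only modestly, if at all; the expected step is a 1.2-fold higher number from compound 2 to compound 3 (0.07 log units; within the scatter), which amounts to no change beyond the scatter. Compound 3 is therefore estimated at 4.5 nM in this assay, with a range from 1.5 nM to 13 nM.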

Compound 3, half-maximal inhibitory concentration: 2.3 nM
Beside the measured number, compound 3's estimate is 2.0-fold (0.29 log units) above it; low and high end bracket the measured number.
By their numbers in this assay, from the lowest: compounds 3 and 2 (each within the scatter of the next); then compound 1.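

In this assay, going by these compounds alone, the change from phenyl to 3-methoxyphenyl on the sulfonyl gives the first step that can be read at this position: a 1.7-fold lower number from compound 2 to compound 3 (0.22 log units; within the scatter). The earlier compounds shown here could not show this, as compound 1 and compound 2 differ in more than one place. The step places compound 3 level with compound 2, so a methoxy on this aromatic carbon, meta to a large group, leaves the number unchanged beyond the scatter in this one pair. Nothing available here explains this outcome.

What the compounds shown leave open is whether another group on this same aromatic carbon, such as an ethoxy, a longer alkoxy chain, an amine or a carboxylic acid, would also leave the number within the scatter of compound 2. Within the data shown here, they also leave open whether a methoxy on any other carbon of this ring would read the same way, and whether the step would hold on a different core, as this single pair covers only one place on one core.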